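Series notes: arylmethyl versus propyl amine on the shared core

The source may report more compounds than this note shows. Statements on the series, on what has been measured and on what is new or still open speak of the compounds shown alone.

Measured in an assay for inhibition of acid-sensing ion channel 3 (Homo sapiens), read by patch clamp, tested at 1 uM; on this read-out lower numbers stand for less inhibition and higher numbers for more inhibition at the one concentration tested (going by the name of the read-out):
compound 1 `NC(N)=NC(=O)c1nc(Cl)c(NCc2ccccc2Cl)nc1N` gives 31%
compound 2 `CCCNc1nc(N)c(C(=O)N=C(N)N)nc1Cl` gives 24%

Compound 2 holds the lowest of the two numbers in this assay; its nearest neighbour is compound 1, and the step of a number 7 percentage points lower from compound 1 to compound 2 (within the scatter) lies within the scatter. Compound 3 `NC(N)=NC(=O)c1nc(Cl)c(NCc2cccc(F)c2)nc1N` is not yet measured. It differs from compound 2 by 3-fluorophenyl in place of ethyl on a saturated chain carbon bound to a nitrogen on an aromatic ring. Within the data shown here, the only bearing step is that from compound 1 to compound 2, which also exchanges an aryl group and ethyl at the same place and gave no change beyond the scatter. No step beyond the scatter is therefore expected for compound 3 in this assay, the estimated step being a number 5 percentage points higher from compound 2 to compound 3 (within the scatter). Compound 3 is expected at 29%, within 15% to 44%.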

Compound 3, a percentage reported as inhibition, at one concentration (the size of the read-out at that concentration, not a potency): 29%
Compound 3: the middle estimate sits on the measured number at the digits printed, within the range that was stated.
By their numbers in this assay, from the lowest: compounds 2, 3 and 1 (each within the scatter of the next).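

In this assay the step is a number 5 percentage points higher from compound 2 to compound 3 (within the scatter), so placing a 3-fluorophenyl ring on the saturated chain carbon instead of ethyl gives no step beyond the scatter. Against the other aryl group, the step is a number 2 percentage points lower from compound 1 to compound 3 (within the scatter), so 3-fluorophenyl and 2-chlorophenyl at this place also cannot be told apart. No available data account for these results.

Open, on these data alone, is whether a group of another kind at this place, such as an amine, a carboxylic acid or a longer chain, would give a step beyond the scatter.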